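This account rests on a few compounds, and the source may have more. Where it says the series, first, only, none or still open, it means among the compounds named here.

Working notes on the series. Compound 1 `CC1CCN(c2nc(C(F)(F)F)ccc2CNC(=O)Nc2cccc3ccc(=O)[nH]c23)CC1` and compound 2 `O=C(NCc1ccc(C(F)(F)F)nc1N1CCCC1)Nc1cccc2c(=O)[nH]ccc12` share the urea-linked core, differing in the substituent carried on the pyridine ring and in the arrangement of the bicyclic lactam. In an assay on CHO cells for agonist activity at transient receptor potential cation channel subfamily V member 1 (Homo sapiens) (a higher number here means that more compound is needed for the effect, a lower number that less compound is needed), compound 1 is recorded as "not active" (no number reported), with no number attached. In this assay, among the compounds with values here, compound 2 gives 258 nM; this is the only number available so far, the other entry being the one without a single value, so compound 2 is the sole reference point for any step.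

Compound 3 `O=C(NCc1ccc(C(F)(F)F)nc1OCC1CCC1)Nc1cccc2c(=O)[nH]ccc12` keeps the core of compound 2 and carries the change (cyclobutylmethoxy in place of pyrrolidin-1-yl on an aromatic carbon). Within the data shown here, no measured pair shows a step of this kind, so there is no precedent to lean on. With the ring nitrogen-linked group exchanged for an oxygen-linked one of similar size, the expectation is a step from compound 2 to compound 3 that is small, of the order of the scatter or slightly toward a weaker effect, a 1.7-fold higher number from compound 2 to compound 3 (0.24 log units; within the scatter). Compound 3 is therefore estimated at 450 nM in this assay, with a range from 120 nM to 2000 nM.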

Compound 3, half-maximal effective concentration: 63.2 nM
Compound 3: middle estimate off by 7.1-fold (0.85 log units), on the high side; measured number outside the range, below it.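

In this assay, within the data shown here, the exchange of pyrrolidin-1-yl for cyclobutylmethoxy on the aromatic carbon next to the ring nitrogen gives a 4.1-fold lower number from compound 2 to compound 3 (0.61 log units; beyond the scatter) and provides the first readable step, one that lies beyond the scatter. This position therefore responds to the group it carries, and it accepts an oxygen-linked cyclobutylmethoxy group in place of a nitrogen-linked ring, even though the counts of hydrogen-bond donors and acceptors are the same for the two groups. No measurement on hand accounts for the size or direction of this step.

Among these compounds, the single pair does not separate the contribution of the linking oxygen from that of the four-membered carbon ring, a question that a cyclobutylmethylamino group or an open butoxy chain at the same place would address. It also leaves open whether the trend extends to larger or smaller ethers such as cyclopentylmethoxy or methoxy, and compound 1, with no number and more than one difference from the others, adds nothing on this point.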